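This account rests on a few compounds, and the source may have more. Where it says the series, first, only, none or still open, it means among the compounds named here.

Compound 1 `CCCNNC(=O)c1ccc(-c2ccccc2)cc1`: 5900 nM
Compound 2 `CCNNC(=O)c1ccccc1`: > 1000000 nM

The test here is an ADME assay on Huh-7 cells (Homo sapiens) for cytotoxicity, read by MTT assay, with a stated time of 3 days; on this read-out higher numbers stand for lower toxicity in this test and lower numbers for higher toxicity in this test. In this assay, within the data shown here, compound 1 gives 5900 nM, the only exact number available so far. Compound 2 is reported at > 1000000 nM, which is a limit of the assay and not a number.

The next compound to be tested is compound 3 `O=C(NO)c1ccc(-c2ccccc2)cc1`. It keeps the core of compound 1 and differs from it in one place: hydroxy in place of propylamino on an amide-type nitrogen. Put simply, hydroxy stands in place of propylamino on an amide-type nitrogen.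

Among the measured compounds shown here, no measured pair of compounds shows this change, so the expectation starts from compound 1 at 5900 nM. A modest step towards higher numbers is expected, though a step in the other direction cannot be ruled out. The expected change is a 2.5-fold higher number from compound 1 to compound 3 (0.41 log units; beyond the scatter). Compound 3 is estimated at 15000 nM, with an expected range from 3000 nM to 80000 nM.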

Compound 3, half-maximal cytotoxic concentration: 30000 nM
Estimate against measurement, compound 3: 2.0-fold (0.30 log units) below; measured number inside the range.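

In this assay, putting hydroxy in place of propylamino on an amide-type nitrogen gives a 5.1-fold higher number from compound 1 to compound 3 (0.71 log units; beyond the scatter). Among these compounds, this is the first measured change at this place, and it shows that, with the shared core kept, the group on this nitrogen can shift the read-out towards lower toxicity in this test. The two groups have the same counts of hydrogen-bond donors and acceptors and neither carries a net charge, so those counts do not separate them; what differs is the loss of the carbon chain and the exchange of nitrogen for oxygen.

Nothing measured here gives a cause for this step. Going by these compounds, it also remains open whether a methoxy group or a longer chain such as butylamino at this place would move the number further or back.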